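The compounds below may be only part of what the source reports. "The series", "measured", "known", "first", "only" and "open" are said of these compounds alone.

Measured in a functional assay on DLD-1 cells (Homo sapiens) for cytotoxicity, with a stated time of 48 h; on this read-out higher numbers stand for weaker inhibition and lower numbers for stronger inhibition:

- Compound 1 `CC(C)CCOc1ccc2oc(/C=C/[S+](C)[O-])cc(=O)c2c1`: 4100 nM
- Compound 2 `CCC(=O)Oc1ccc2oc(/C=C/[S+](C)[O-])cc(=O)c2c1`: 9000 nM

Of these two compounds, compound 2 carries the higher number at 9000 nM, so it is the weaker inhibitor in this assay. Compound 3 `CC(C)C(=O)Oc1ccc2oc(/C=C/[S+](C)[O-])cc(=O)c2c1` has not yet been measured. It differs from compound 2 by one change, propanoyl to isopropylcarbonyl: methyl in place of hydrogen on a saturated chain carbon bound to a carbonyl carbon and a saturated chain carbon.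

For the measured compounds named here, only one measured step bears on this, and only indirectly. a 2.2-fold higher number from compound 1 to compound 2 (0.34 log units; beyond the scatter) is a modest step, and it exchanges an isopentyl group for propanoyl, so it does not test the added methyl itself. Going by the values given here, with compound 1 at 4100 nM as the sole comparison, a small move towards lower numbers seems the most that can be expected, and probably nothing beyond the scatter. The expected step is a 1.2-fold lower number from compound 2 to compound 3 (0.08 log units; within the scatter). Compound 3 is estimated at 7500 nM, with an expected range of 3500 nM to 16000 nM.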

Compound 3, half-maximal inhibitory concentration: 9100 nM
Compound 3: middle estimate off by 1.2-fold (0.08 log units), on the low side; the measured number falls inside the stated range.
By their numbers in this assay, from the lowest: compound 1; then compounds 2 and 3 (each within the scatter of the next).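

In this assay, methyl in place of hydrogen on a saturated chain carbon bound to a carbonyl carbon and a saturated chain carbon gives a 1.0-fold higher number from compound 2 to compound 3 (0.00 log units; within the scatter) and so does not separate the two acyl groups. Branching at this carbon, tested here for the first time, therefore leaves the read-out unchanged, turning propanoyl into isopropylcarbonyl without any detectable shift. The isopentyl group keeps its separation from the branched group too, with a 2.2-fold higher number from compound 1 to compound 3 (0.35 log units; beyond the scatter) on the oxygen on an aromatic ring, but no independent measurement bears on these results.

The compounds shown leave open whether a longer acyl chain or a benzoyl group on the same oxygen would separate from compound 2 and compound 3. They also leave open what a free hydroxyl or an amine-bearing chain would give there.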